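The source may hold more compounds than are shown below. What is called first, only, known or untested is meant among the compounds shown, and "the series" means these compounds.

Working notes on substitution at one aromatic carbon of the shared core, followed in an ADME assay (liver) for metabolic stability, with Liver microsome (Homo sapiens) as the target, using microsomes and NADPH, with a stated time of 30 min, tested at 1 uM; a higher number here means faster removal of the compound, a lower number slower removal. Compound 1 `CC(C)(C)n1cc(-c2cc(C(O)(C(F)(F)F)C(F)(F)F)cnc2N2CCN(S(=O)(=O)c3ccc(N)nc3)CC2)cn1` gives 86 mL.min-1.g-1 in this read-out. Compound 2 `CS(=O)(=O)c1ccc(-c2cc(C(O)(C(F)(F)F)C(F)(F)F)cnc2N2CCN(S(=O)(=O)c3ccc(N)nc3)CC2)cc1` gives 32 mL.min-1.g-1 and compound 3 `Nc1ccc(S(=O)(=O)N2CCN(c3ncc(C(O)(C(F)(F)F)C(F)(F)F)cc3-c3cncc(F)c3)CC2)cn1` gives 24 mL.min-1.g-1. Compound 3 therefore stands with compound 2 at the low end of the three numbers, the gap being a 1.3-fold lower number from compound 2 to compound 3 (0.12 log units; within the scatter) and well short of the distance to compound 1.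

Next is compound 4 `Nc1ccc(S(=O)(=O)N2CCN(c3ncc(C(O)(C(F)(F)F)C(F)(F)F)cc3-c3ccc4sccc4c3)CC2)cn1`, with 1-benzothiophen-5-yl in place of 5-fluoropyridin-3-yl on an aromatic carbon on an aromatic carbon. Two measured steps at this place bear on it: a 2.7-fold lower number from compound 1 to compound 2 (0.43 log units; beyond the scatter) and a 3.6-fold lower number from compound 1 to compound 3 (0.55 log units; beyond the scatter), both modest. No measured group closely resembles the entering one, so the guidance is rough. Like the group of compound 1 at 86 mL.min-1.g-1, it carries neither fluorine nor sulfonyl, so a modest rise of similar size is expected. The expected change is a 2.5-fold higher number from compound 3 to compound 4 (0.40 log units; beyond the scatter) in this assay. The estimate for compound 4 is 60 mL.min-1.g-1, with an expected range of 28 mL.min-1.g-1 to 130 mL.min-1.g-1.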

Compound 4, intrinsic clearance in microsomes: 48 mL.min-1.g-1
Beside the measured number, compound 4's estimate is 1.3-fold (0.10 log units) above it, within the range that was stated.
By their numbers in this assay, from the lowest: compounds 3, 2, 4 and 1 (each within the scatter of the next, the first and the last beyond it).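

For the compounds shown here, the steps of a 2.0-fold higher number from compound 3 to compound 4 (0.30 log units; within the scatter) and a 1.5-fold higher number from compound 2 to compound 4 (0.18 log units; within the scatter) and a 1.8-fold lower number from compound 1 to compound 4 (0.25 log units; within the scatter) all lie within the scatter in this assay, so 1-benzothiophen-5-yl, with its five-membered and six-membered aromatic rings, is the one group at this aromatic carbon not set apart from either end of the series. It carries neither fluorine nor sulfonyl, yet it cannot be placed with compound 1 any more than with compound 2 or compound 3, so the presence or absence of those atoms does not sort these four compounds into two clear sets. Nothing on hand accounts for where compound 4 falls.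

Open, going by these compounds, is how a plain phenyl or a group carrying an amine, such as piperidin-4-yl, would stand at this carbon. Also open, on these data alone, is whether a carboxylic acid on the entering ring would give a step beyond the scatter from compound 4.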